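The source may report more compounds than this note shows. Statements on the series, on what has been measured and on what is new or still open speak of the compounds shown alone.

Measured compounds:
Compound 1 `Fc1cc2nc(-c3cncnc3)n(C3CC3)c2cc1F` gives 22 nM in an assay on cells for inhibition of cytochrome P450 11B2, mitochondrial (Homo sapiens), read by HPLC, with a stated time of 90 min; on this read-out lower numbers stand for stronger inhibition and higher numbers for weaker inhibition.
Compound 2 `CN(C)c1ncncc1-c1nc2cc(F)c(F)cc2n1C1CC1` gives 29 nM in this assay.

Within the data shown here, compound 2 has the higher of the two numbers, but its only neighbour is compound 1, and the single measured step of a 1.3-fold higher number from compound 1 to compound 2 (0.12 log units; within the scatter) lies within the scatter, so the two cannot be ranked. Compound 3 `Fc1cc2nc(-c3cncnc3NCCC(F)(F)F)n(C3CC3)c2cc1F` has not yet been measured; it differs from compound 2 by (3,3,3-trifluoropropyl)amino in place of dimethylamino on an aromatic carbon. Among the measured compounds shown here, the one step that bears on this position, a 1.3-fold higher number from compound 1 to compound 2 (0.12 log units; within the scatter), shows that putting a dimethylamino group on this carbon in place of hydrogen left the number essentially where it was. For the measured compounds named here, no measured step tells what the longer (3,3,3-trifluoropropyl)amino group does at the same carbon. On this basis, no change beyond the scatter is expected in this assay for compound 3, and the expected step is a 1.2-fold higher number from compound 2 to compound 3 (0.08 log units; within the scatter). Compound 3 is therefore estimated at about 35 nM, within a range from 12 nM to 100 nM.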

Compound 3, half-maximal inhibitory concentration: 3 nM
For compound 3 the middle estimate is 12-fold (1.07 log units) above the measured one; measured number outside the range, below it.
By their numbers in this assay, from the lowest: compound 3; then compounds 1 and 2 (each within the scatter of the next).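

In this assay, (3,3,3-trifluoropropyl)amino in place of dimethylamino gives a 9.7-fold lower number from compound 2 to compound 3 (0.99 log units; beyond the scatter), so what this aromatic carbon carries can matter, which the earlier pair of compounds did not reveal. Set against plain hydrogen, the same group gives a 7.3-fold lower number from compound 1 to compound 3 (0.87 log units; beyond the scatter), showing that a substituent here can lower the number and not merely leave it level, as dimethylamino did. No measurement shown offers a reason for this drop.

Which part of the new group counts remains open, as its longer chain, its fluorine atoms and its hydrogen-bond donor all enter in a single step. A plain propylamino group or a methylamino group on this carbon would help to pull these apart.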